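The source may hold more compounds than are shown below. What is called first, only, known or untested is meant among the compounds shown, and "the series" means these compounds.

Working notes on the series. In a physicochemical assay for solubility, in phosphate buffer, measured as kinetic solubility, with a stated time of 24 h, at pH 7.4, tested at 100 uM (a lower number here means a less soluble compound, a higher number a more soluble compound), compound 1 `CC(C)n1cc(C(N)=O)c2cnc(Nc3ccnc(-c4cnn(S(=O)(=O)C5CC5)c4)n3)cc21` gives < 1000 nM, which is a limit of the assay and not a number. Compound 2 `CC(C)n1cc(C(=O)NC2COC2)c2cnc(Nc3ccnc(-c4cnn(S(=O)(=O)C5CC5)c4)n3)cc21` gives 7000 nM. Compound 3 `CC(C)n1nc(N2CC(CO)C2)c2cnc(Nc3ccnc(-c4cnn(S(=O)(=O)C5CC5)c4)n3)cc21` gives 3000 nM, the lower of the two actual numbers.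

Compound 4 `CC(C)c1nn(C(C)C)c2cc(Nc3ccnc(-c4cnn(S(=O)(=O)C5CC5)c4)n3)ncc12` carries isopropyl in place of 3-(hydroxymethyl)azetidin-1-yl on an aromatic carbon.

For the measured compounds named here, only one measured step offers any guide: an at least 7.0-fold higher number from compound 1 to compound 2 (0.84 log units; beyond the scatter). It replaces hydrogen on an amide-type nitrogen with oxetan-3-yl, so it lies at a different place and starts from a limit, which makes it weak evidence. There, adding a ring with a hetero atom went with a higher number. Here such a ring leaves, so a move of moderate size towards a lower number in this assay is expected.

The estimated change is a 3.8-fold lower number from compound 3 to compound 4 (0.57 log units; beyond the scatter). For compound 4 the expected value is 800 nM, with an estimated range of 200 nM to 3000 nM. The assay may well return only a limit for compound 4.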

Compound 4, solubility: < 1000 nM
Compound 4: no number, only a limit; the forecaster's own chance of this, stated with the estimate: 60%; the middle value is on the limit's open side.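

In this assay, the position on an aromatic carbon of the five-membered aromatic ring now has a direct comparison, and isopropyl in place of 3-(hydroxymethyl)azetidin-1-yl gives an at least 3.0-fold lower number from compound 3 to compound 4 (0.47 log units; beyond the scatter). The entry for compound 4 is a limit of the assay and not a number, so the step fixes only a minimum size for the change. This limit now applies to two compounds in the series: the limit of < 1000 nM in this assay, at which 2 of the 4 values shown sit.

The swap removes the four-membered ring, the hydrogen-bond donor and the hydrogen-bond acceptors together, and the compounds shown do not separate these features. On these data alone, whether the step follows the ring or the hydroxymethyl arm remains open, as does the outcome with a simple amine such as dimethylamino or with a carboxylic acid on this carbon.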